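Cyano in place of bromo: notes on compound 4

The compounds below may be only part of what the source reports. "The series", "measured", "known", "first", "only" and "open" are said of these compounds alone.

Measured in an ADME assay on the whole organism (Mus musculus, strain CD-1) for pharmacokinetics, at a dose of 10 mg/kg by the oral route; a higher number here means more compound in the circulation at the dose given, a lower number less compound in the circulation:
- compound 1 `COc1cc([C@](O)(CCN(C)C)[C@@H](c2cc3cc(Br)ccc3nc2OC)c2ccnc(OC)c2OC)cc(OC2CCC2)n1`: 8400 ng.h/mL
- compound 2 `COc1cc([C@](O)(CCN(C)C)[C@@H](c2cc3cc(C#N)ccc3nc2OC)c2cccc(C)c2F)cc(OC(F)F)n1`: 8600 ng.h/mL
- compound 3 `COc1cc([C@](O)(CCN(C)C)[C@@H](c2cc3cc(Br)ccc3nc2OC)c2ccnc(OC)c2OC)cc(OC(F)F)n1`: 9800 ng.h/mL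

In this assay compound 3 gives 9800 ng.h/mL, and all three compounds lie within the scatter of one another, so the three numbers form a single level.

The next structure is compound 4 `COc1cc([C@](O)(CCN(C)C)[C@@H](c2cc3cc(C#N)ccc3nc2OC)c2ccnc(OC)c2OC)cc(OC(F)F)n1`, which differs from compound 3 by one change: cyano in place of bromo on an aromatic carbon. In words, cyano takes the place of bromo on an aromatic carbon.

Among the measured compounds shown here, no measured step covers this exchange. For the measured compounds named here, the one measured step, a 1.2-fold higher number from compound 1 to compound 3 (0.07 log units; within the scatter), lies at another place in the structure and stays within the scatter. Compound 2 also carries a cyano and gives 8600 ng.h/mL, but it differs from compound 4 elsewhere too, so it offers only indirect support. With so little evidence, the range has to stay wide.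

No step beyond the scatter is expected, and the estimated change is a 1.2-fold lower number from compound 3 to compound 4 (0.09 log units; within the scatter). For compound 4 the expected value is 8000 ng.h/mL, with an estimated range from 3500 ng.h/mL to 16000 ng.h/mL.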

Compound 4, area under the concentration-time curve: 3000 ng.h/mL
The estimate for compound 4 lay 2.7-fold (0.43 log units) above the measured number; the measured number lies below the stated range.
By their numbers in this assay, from the lowest: compound 4; then compounds 1, 2 and 3 (each within the scatter of the next).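

In this assay, among the compounds shown here, the aromatic carbon that carried bromo proves sensitive to exchange: cyano in place of bromo gives the first step beyond the scatter (a 3.3-fold lower number from compound 3 to compound 4 (0.51 log units; beyond the scatter)). The exchange at the other place, 2,3-dimethoxypyridin-4-yl in place of 2-fluoro-3-methylphenyl on the saturated chain carbon, also lowers the number (a 2.9-fold lower number from compound 2 to compound 4 (0.46 log units; beyond the scatter)), so among the compounds shown neither cyano nor 2,3-dimethoxypyridin-4-yl goes with the lower level on its own, and only compound 4 carries the two together. Nothing at hand explains this drop.

The compounds shown leave open whether the loss belongs to cyano specifically or would also appear with another group on this aromatic carbon, such as chloro, methyl or a primary carboxamide, and whether it would persist with cyclobutyl on the oxygen in place of difluoromethyl. The area under the curve after an oral dose also does not separate uptake from removal, so the route by which compound 4 reaches its lower number remains undefined.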